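The source may report more compounds than this note shows. Statements on the series, on what has been measured and on what is new or still open speak of the compounds shown alone.

Compound 1 `Cc1c(OCCCCOc2ccc(C(=O)O)cc2Cl)ccc(C(=O)CC2CCCC2)c1O` gives the higher of the two values recorded in an assay on HEK293 cells for positive allosteric modulation of metabotropic glutamate receptor 2 (Rattus norvegicus), read by thallium flux, with a stated time of 2.5 min (a higher number here means a larger maximal response, a lower number a smaller maximal response), namely 82.2%. Compound 2 `CCC(=O)c1ccc(OCCCCOc2cccc(C(=O)O)c2C)c(C)c1O` gives 71.3% in this assay, a number below compound 1 by more than the usual scatter. Compound 3 `COc1ccc(C(=O)O)cc1OCCCCOc1ccc(C(=O)CC2CCCC2)c(O)c1C` has not yet been measured. The change from compound 1 to compound 3 is 5-carboxy-2-methoxyphenyl in place of 4-carboxy-2-chlorophenyl on an oxygen on a saturated carbon. For the measured compounds named here, no measured pair isolates this change, so the direction is open. A step no larger than the scatter is expected for the maximal response, a number 6.2 percentage points lower from compound 1 to compound 3 (within the scatter). Compound 3 is expected to reach 76% in this assay, within a range of 56% to 94%.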

Compound 3, largest response reached (reported as percent of maximum), in percent of the reference or control that the assay uses: 91.8%
Compound 3: the middle estimate sits 15.8 percentage points below what was measured; the measured number falls inside the stated range.
By their numbers in this assay, from the lowest: compound 2; then compounds 1 and 3 (each within the scatter of the next).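

In this assay, 5-carboxy-2-methoxyphenyl in place of 4-carboxy-2-chlorophenyl on an oxygen on a saturated carbon gives a number 9.6 percentage points higher from compound 1 to compound 3 (within the scatter), so the maximal response of the two compounds cannot be told apart. This position therefore accepts the exchange of one substituted carboxyphenyl group for the other. No available data explain this result.

The step alters the methoxy-for-chlorine exchange and the carboxy placement together, leaving their separate contributions unresolved. Also open, on these data alone, is how a primary amide in place of the carboxylic acid would read out here.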